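Removing a fluoro from the sulfonyl aryl ring

The compounds below may be only part of what the source reports. "The series", "measured", "known", "first", "only" and "open" are said of these compounds alone.

This account follows three measured compounds and one still to be measured, all sharing one core. Compound 1 `Cc1ccccc1S(=O)(=O)N1CCN(c2ccc(C(=O)NCc3cccs3)nn2)CC1` gives 0.92 in an ADME assay on microsomes from liver (Homo sapiens), read by LC-MS, using NADPH, tested at 10 uM; on this read-out lower numbers stand for lower hepatic extraction and higher numbers for higher hepatic extraction. Compound 2 `Cc1ccccc1S(=O)(=O)N1CCN(c2ccc(C(=O)NCc3cncs3)nn2)CC1` gives 0.59. Compound 3 `Cc1ccc(F)cc1S(=O)(=O)N1CCN(c2ccc(C(=O)NCc3ccc(F)cc3)nn2)CC1` gives 0.78, which puts compound 3 second highest of the three numbers, below compound 1 and above compound 2, both gaps lying beyond the scatter.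

Among the measured compounds shown here, the only step between measured compounds that differ in one place is a number 0.33 lower from compound 1 to compound 2 (beyond the scatter), a change of 1,3-thiazol-5-yl in place of thiophen-2-yl on a saturated chain carbon bound to an amide-type nitrogen.

Compound 4 `Cc1ccccc1S(=O)(=O)N1CCN(c2ccc(C(=O)NCc3ccc(F)cc3)nn2)CC1` differs from compound 3 in one place: hydrogen in place of fluoro on an aromatic carbon. The (5-fluoro-2-methylphenyl)sulfonyl group becomes a (2-methylphenyl)sulfonyl group. For the measured compounds named here, no measured step touches this part of the structure, so the step from compound 1 to compound 2 offers no guide here; it concerns a different ring. Going by the values given here, with no comparable step, the expectation for compound 4 is a step of a number 0.020 higher from compound 3 to compound 4 (within the scatter), that is, no change beyond the scatter. Compound 4 is therefore estimated at 0.8, with a range from 0.65 to 0.92.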

Compound 4, hepatic extraction ratio: 0.56
Compound 4: the middle estimate sits 0.24 above what was measured; the measured number lies below the stated range.
By their numbers in this assay, from the lowest: compounds 4 and 2 (each within the scatter of the next); then compound 3; then compound 1.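

In this assay, among the compounds shown here, the fluoro on the sulfonyl aryl ring proves to matter: a number 0.22 lower from compound 3 to compound 4 (beyond the scatter), so hydrogen in place of fluoro on this aromatic carbon, para to a methyl group, gives a step beyond the scatter, and this is the first reading of any change on that ring. With the (2-methylphenyl)sulfonyl group held constant, the group on the amide can now be read more widely: a number 0.36 lower from compound 1 to compound 4 (beyond the scatter) for 4-fluorophenyl in place of thiophen-2-yl, while a number 0.030 lower from compound 2 to compound 4 (within the scatter) for 4-fluorophenyl in place of 1,3-thiazol-5-yl stays within the scatter, so these two groups cannot be told apart here. Nothing available bears on the cause of these steps.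

On these data alone, the fluoro-to-hydrogen step is known from one pair only, with 4-fluorophenyl on the chain, so whether it would hold with thiophen-2-yl or 1,3-thiazol-5-yl in that place remains open. Also open, as far as these compounds go, is how chloro, methoxy or nitrile on the same aromatic carbon would compare with fluoro and hydrogen on this read-out.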